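A few compounds are considered here, and "the series" means these few. Any claim that something is new, unique, unknown or untested is made for them only; others in the source may bear on it.

Compound 1 `CCCSc1nc(N/N=C(\C)c2ccc(O)cc2)c2nnn(Cc3ccccc3)c2n1`: in a functional assay on ECa-109 cells (Homo sapiens) for antiproliferative activity, read by MTT assay, with a stated time of 72 h (a higher number here means a weaker inhibitor, a lower number a stronger inhibitor), compound 1 gives 32500 nM.
Compound 2 `C#CCSc1nc(N/N=C(\C)c2ccccc2O)c2nnn(Cc3ccccc3)c2n1`: in this assay compound 2 gives 5250 nM.

Compound 2 stands lowest of the two numbers, and the number of compound 1 lies above it by a gap beyond the usual scatter. Compound 3 `C/C(=N\Nc1nc(SCc2ccccc2)nc2c1nnn2Cc1ccccc1)c1ccccc1O` differs from compound 2 by phenyl in place of ethynyl on a saturated chain carbon bound to a sulfur. Going by the values given here, no step between measured compounds informs this change, so the expected step of a 1.0-fold higher number from compound 2 to compound 3 (0.02 log units; within the scatter) is small, with no direction beyond the scatter. Compound 3 is therefore estimated at 5500 nM, within a range from 2000 nM to 16000 nM.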

Compound 3, half-maximal inhibitory concentration: 1770 nM
Beside the measured number, compound 3's estimate is 3.1-fold (0.49 log units) above it; the measured number lies below the stated range.
By their numbers in this assay, from the lowest: compound 3; then compound 2; then compound 1.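

At the saturated chain carbon bound to a sulfur, the group proves to matter in this assay: phenyl in place of ethynyl gives a 3.0-fold lower number from compound 2 to compound 3 (0.47 log units; beyond the scatter). Going by these compounds alone, this is the first single change read at this position, and it shows that a six-membered aromatic ring of carbon only is tolerated there and goes with a stronger inhibitor. Nothing shown explains the step. From the compounds shown here alone, whether the ring itself matters, or simply a longer substituent, remains open. A pyridine ring, a cyclohexyl group or an amine at that place could separate these readings.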